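A few compounds are considered here, and "the series" means these few. Any claim that something is new, unique, unknown or untested is made for them only; others in the source may bear on it.

Working notes on the series. Three compounds share one core and differ only in the aryl group on an amide-type nitrogen in a ring. Compound 1 `O=C1c2cc(COc3ccccc3)nn2CCN1c1ccc(F)c(F)c1` carries 3,4-difluorophenyl there, and in a functional assay on HEK293 cells for positive allosteric modulation of metabotropic glutamate receptor 5 (Homo sapiens), read by calcium flux (a lower number here means a smaller maximal response, a higher number a larger maximal response), compound 1 gives 81%. Compound 2 `COc1ccc(N2CCn3nc(COc4ccccc4)cc3C2=O)cc1` carries 4-methoxyphenyl, and in this assay compound 2 gives 58%. Compound 3 `O=C1c2cc(COc3ccccc3)nn2CCN1c1cccnc1` carries pyridin-3-yl; in this assay compound 3 gives 64%, the second highest of the three numbers: a number 6 percentage points higher from compound 2 to compound 3 (within the scatter), whereas a number 17 percentage points lower from compound 1 to compound 3 (beyond the scatter). The remaining step is a number 23 percentage points lower from compound 1 to compound 2 (beyond the scatter).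

Compound 4 `Cc1ccc(N2CCn3nc(COc4ccccc4)cc3C2=O)nc1` is the next member and differs from compound 3 as follows: 5-methylpyridin-2-yl in place of pyridin-3-yl on an amide-type nitrogen in a ring. For the measured compounds named here, no measured step exchanges one pyridyl for another. Going by the values given here, the steps that bear on the change are the aryl exchanges at this nitrogen, and of those only the two leading away from 3,4-difluorophenyl moved the maximal response beyond the scatter, while the exchange between 4-methoxyphenyl and pyridin-3-yl stayed within it. A small step is therefore expected, a number 2 percentage points lower from compound 3 to compound 4 (within the scatter), its direction uncertain. Compound 4 is estimated at 62% in this assay, in the range 48% to 78%.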

Compound 4, largest response reached (Emax), in percent of the reference or control that the assay uses: 76%
Beside the measured number, compound 4's estimate is 14 percentage points below it; the measured number falls inside the stated range.
By their numbers in this assay, from the lowest: compounds 2 and 3 (each within the scatter of the next); then compounds 4 and 1 (each within the scatter of the next).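

In this assay the exchange of one pyridyl group for another is not silent (a number 12 percentage points higher from compound 3 to compound 4 (beyond the scatter)), so at this amide-type nitrogen in a ring, the presence of a six-membered aromatic ring with one hetero atom does not by itself set the maximal response. The 5-methylpyridin-2-yl group also separates from 4-methoxyphenyl (a number 18 percentage points higher from compound 2 to compound 4 (beyond the scatter)), and it is the only group shown whose exchange for 3,4-difluorophenyl stays within the scatter (a number 5 percentage points lower from compound 1 to compound 4 (within the scatter)), so a pyridyl group can take the place of that difluorophenyl group without a measurable loss of maximal response. No measurement at hand accounts for the step between the two pyridyl compounds.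

This exchange combines two differences, the pyridin-2-yl attachment and the 5-methyl group, and the compounds shown do not separate them; the unsubstituted pyridin-2-yl group would. Also open, as far as these compounds go, is whether the maximal response holds when the methyl gives way to a longer chain such as ethyl or to an amine at the same ring position of the pyridin-2-yl group.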